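The source may report more compounds than this note shows. Statements on the series, on what has been measured and on what is new or still open speak of the compounds shown alone.

Measured in a functional assay on SK-MEL-147 cells (Homo sapiens) for cytotoxicity, read by MTT assay, with a stated time of 24 h; on this read-out higher numbers stand for an effect only at larger amounts of compound and lower numbers for an effect already at smaller amounts:
Compound 1 `CCOC(=O)c1cc([Se]c2ccc3cc(OC)ccc3c2)c2cc(OC)ccc2n1`: 30800 nM
Compound 2 `CCOC(=O)c1cc([Se]c2ccc3ccccc3c2)c2cc(OC)ccc2n1`: 32200 nM

In this assay, among the measured compounds shown here, compound 1 stands level with compound 2, the only other compound measured. Compound 3 `CCOC(=O)c1cc([Se]c2ccc3cc(OC)ccc3c2)c2cc(Cl)ccc2n1` differs from compound 1 as follows: chloro in place of methoxy on an aromatic carbon. For the measured compounds named here, one measured step bears on this only indirectly: a 1.0-fold higher number from compound 1 to compound 2 (0.02 log units; within the scatter). It removes the other methoxy, not the one replaced here, and lies within the scatter. No shift beyond the scatter is therefore expected in this assay. The expected step is a 1.1-fold lower number from compound 1 to compound 3 (0.04 log units; within the scatter). Compound 3 is estimated at 28000 nM, with an expected range of 11000 nM to 65000 nM.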

Compound 3, half-maximal effective concentration: 16200 nM
Compound 3: middle estimate off by 1.7-fold (0.24 log units), on the high side; the range from low to high includes it.
By their numbers in this assay, from the lowest: compounds 3, 1 and 2 (each within the scatter of the next).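

Chloro in place of methoxy on this aromatic carbon of the shared core, the first change at this position, gives a 1.9-fold lower number from compound 1 to compound 3 (0.28 log units; within the scatter) in this assay. This position therefore tolerates the exchange of methoxy for chloro without a shift beyond the scatter, as the other methoxy tolerated replacement by hydrogen. Nothing measured on these compounds accounts for the size of the step. Open, from the compounds shown here alone, is whether an amine, a carboxylic acid or a longer chain at this position would move the number beyond the scatter. Also open, going by these compounds, is whether chloro in place of the other methoxy would do so.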